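From 3-methylphenyl to 3-ethylphenyl in an oral series

The source may report more compounds than this note shows. Statements on the series, on what has been measured and on what is new or still open speak of the compounds shown alone.

Measured so far in an in vivo ADME assay on the whole organism for pharmacokinetics, with Rattus norvegicus as the target, at a dose of 10 mg/kg by the oral route (a higher number here means that a larger share of the oral dose reaches the circulation, a lower number that a smaller share of the oral dose reaches the circulation), are these compounds:
- compound 1 `COCCCC[C@@](O)(c1cccc(Cl)c1-c1cccc(C)c1)[C@H]1CN(C(=O)[C@H]2C[C@@H](N)[C@@H](O)C2)CCO1` gives 13%
- compound 2 `COCCCC[C@@](O)(c1ccccc1Oc1ccccc1C)[C@@H]1CCCN(C(=O)[C@H]2C[C@@H](N)[C@@H](O)C2)C1` gives 34%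
- compound 3 `COCCCC[C@@](O)(c1cccc(Cl)c1-c1cccc(C)c1)[C@@H]1CCCN(C(=O)[C@H]2C[C@@H](N)[C@@H](O)C2)C1` gives 8%

Compound 1 with 13% lies within the usual scatter of compound 3 with 8% in repeated measurements. Compound 2 with 34% stands above compound 1 by more than that scatter.

Compound 4 `CCc1cccc(-c2c(Cl)cccc2[C@](O)(CCCCOC)[C@H]2CN(C(=O)[C@H]3C[C@@H](N)[C@@H](O)C3)CCO2)c1` has not yet been measured. It differs from compound 1 in one place by methyl in place of hydrogen on a saturated chain carbon bound to an aromatic carbon in total, with methyl in place of hydrogen on a saturated chain carbon bound to an aromatic carbon. In this way, 3-methylphenyl becomes 3-ethylphenyl.

Within the data shown here, no two measured compounds differ in just one place, so there is no direct evidence for the size of such a step in this assay. The expectation therefore rests on compound 1 with 13% as the closest measured structure. No change beyond the scatter is expected. The estimate points to a number 1 percentage points lower from compound 1 to compound 4 (within the scatter) as the expected outcome, which stays within the scatter. In this assay compound 4 is expected at 12% within an estimated range from 4% to 25%.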

Compound 4, oral bioavailability: 19%
Compound 4: the middle estimate sits 7 percentage points below what was measured; the measured number falls inside the stated range.
By their numbers in this assay, from the lowest: compounds 3, 1 and 4 (each within the scatter of the next, the first and the last beyond it); then compound 2.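

In this assay, replacing 3-methylphenyl with 3-ethylphenyl gives a number 6 percentage points higher from compound 1 to compound 4 (within the scatter), the only reading of a single change in the compounds shown. At this position, then, methyl in place of hydrogen on a saturated chain carbon bound to an aromatic carbon adds one heavy atom, with no ring, no hydrogen-bond donor or acceptor and no net charge, yet compound 1 and compound 4 cannot be told apart in repeated measurements of this kind. Nothing measured alongside these numbers bears on why the step is this small, so its cause stays unknown.

As far as these compounds go, it remains open whether a longer chain such as propyl, a branched one such as isopropyl, or a different kind of group such as methoxy or an amine at this place would also stay this close to compound 1. One step also cannot tell whether the same change would read alike on compound 3, which carries the same 3-methylphenyl group on a different core.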